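Butoxy chain and bromine on a pyrazolopyrimidinone series

A few compounds are considered here, and "the series" means these few. Any claim that something is new, unique, unknown or untested is made for them only; others in the source may bear on it.

Compound 1 `CCCOc1ccccc1-c1nc2c(cnn2-c2ccccc2)c(=O)[nH]1` serves as the starting point of the set. In a functional assay on corpus cavernosum (Rattus norvegicus) for activation (on this read-out higher numbers stand for larger maximal responses and lower numbers for smaller maximal responses), compound 1 gives 150%. Compound 2 `CCCCOc1ccccc1-c1nc2c(cnn2-c2ccccc2)c(=O)[nH]1` differs from it in one place, (methyl in place of hydrogen on a saturated chain carbon, three bonds along the chain from an oxygen on an aromatic ring), and in this assay compound 2 gives 170%, so that the chain extension yields a number 20 percentage points higher from compound 1 to compound 2 (beyond the scatter). Compound 3 `CCCOc1ccccc1-c1nc2c(cnn2-c2ccc(Br)cc2)c(=O)[nH]1` carries a different change on the other ring, (bromo in place of hydrogen on an aromatic carbon), which is also how the core of compound 3 differs from the core of compound 1. In this assay compound 3 gives 140%, a result that amounts to a number 10 percentage points lower from compound 1 to compound 3 (within the scatter). Compound 3 and compound 1 therefore cannot be told apart on this read-out, while compound 2 stands apart from both of them.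

The unmeasured compound 4 `CCCCOc1ccccc1-c1nc2c(cnn2-c2ccc(Br)cc2)c(=O)[nH]1` differs from compound 3 by methyl in place of hydrogen on a saturated chain carbon, three bonds along the chain from an oxygen on an aromatic ring, at a place described in exactly the same words as for the change from compound 1 to compound 2, so the two changes are the same. The expectation for compound 4 is that this change in this assay gives a step of about a number 20 percentage points higher from compound 3 to compound 4 (beyond the scatter), close to the earlier one, because the same change on the unbrominated core produced a number 20 percentage points higher from compound 1 to compound 2 (beyond the scatter). Compound 4 is accordingly expected to reach about 160%, with a range from 145% to 175%.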

Compound 4, largest response reached (Emax), in percent of the reference or control that the assay uses: 160%
For compound 4 middle estimate and measured number coincide at the digits printed; the range from low to high includes it.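

Carried onto the core that bears the bromo group, the change from propyl to butyl gives a number 20 percentage points higher from compound 3 to compound 4 (beyond the scatter) in this assay, and this step matches the one seen on the core without bromo: the same change on two cores in this assay, a number 20 percentage points higher (beyond the scatter) from compound 1 to compound 2 and a number 20 percentage points higher (beyond the scatter) from compound 3 to compound 4, 0 percentage points apart, within the scatter of two such steps. Read the other way round, bromo in place of hydrogen on an aromatic carbon gives a number 10 percentage points lower from compound 2 to compound 4 (within the scatter), so that on the butyl compounds, as on the propyl compounds, the bromo change stays inside the usual scatter: the same change on two cores in this assay, a number 10 percentage points lower (within the scatter) from compound 1 to compound 3 and a number 10 percentage points lower (within the scatter) from compound 2 to compound 4, 0 percentage points apart, within the scatter of two such steps. The two changes therefore behave as independent of each other within these four compounds, but this rests on a single square of compounds and a single read-out, and it does not show that the chain step would hold on any other core or in any other assay.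

The compounds shown leave open whether the rise continues with a longer chain such as pentyl, or whether it stops or reverses once the chain passes butyl. They also leave open what a chloro or a methoxy group would do in place of the bromo, and whether the chain step would survive that replacement as it survives the bromo group here.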